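Adding a Second Chloro to a Thioxo-imidazolidine Aryl Ring

The compounds below may be only part of what the source reports. "The series", "measured", "known", "first", "only" and "open" are said of these compounds alone.

Compound 3 `O=CN1CCN(c2ccc(Cl)cc2)C1=S` gives 25000 nM in a functional assay on SK-OV-3 cells (Homo sapiens) for inhibition, read by sulforhodamine B assay, with a stated time of 48 h; on this read-out higher numbers stand for weaker inhibition of growth and lower numbers for stronger inhibition of growth. Its number is the smallest of the three shown, yet compound 2 `N#C/C(=C\N1CCN(C(=O)c2ccco2)C1=S)C(=O)c1ccccc1` with 37400 nM and compound 1 `N#C/C(=C\N1CCN(C(=O)c2ccco2)C1=S)C(=O)Nc1ccc(Cl)cc1` with 41200 nM both lie within the scatter of it. Going by the values given here, the one measured step, a 1.1-fold lower number from compound 1 to compound 2 (0.04 log units; within the scatter), concerns a different part of the molecule and says nothing about the aryl ring. Compound 4 `O=CN1CCN(c2ccc(Cl)c(Cl)c2)C1=S` differs from compound 3 by chloro in place of hydrogen on an aromatic carbon. Among the compounds with values here, no measured step covers a change of this kind, so the record offers no direction. The estimate for compound 4 is therefore 22000 nM in this assay, within 8000 nM to 55000 nM. This expected step, a 1.1-fold lower number from compound 3 to compound 4 (0.06 log units; within the scatter), is judged to be none beyond the scatter.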

Compound 4, concentration for 50% growth inhibition: 18900 nM
The estimate for compound 4 lay 1.2-fold (0.07 log units) above the measured number; the range from low to high includes it.
By their numbers in this assay, from the lowest: compounds 4, 3, 2 and 1 (each within the scatter of the next, the first and the last beyond it).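

In this assay the entering chloro, ortho to a chloro group and meta to a group of 8 heavy atoms, gives a step that stays within the scatter (a 1.3-fold lower number from compound 3 to compound 4 (0.12 log units; within the scatter)). Going by these compounds alone, this is the first reading of a change on this aryl ring, and it shows no shift that can be told from the scatter. No evidence on any property of these compounds bears on this result.

Going by these compounds, whether an amine, a methoxy group or a carboxylic acid at this position would move the number beyond the scatter remains open. Also open, on these data alone, is whether the same chloro change would give a similar step on the core of compound 1.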